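The source may report more compounds than this note shows. Statements on the series, on what has been measured and on what is new or still open speak of the compounds shown alone.

Compound 2 `Nc1cc(Cc2ccn(Cc3cccc(-c4ccccc4)c3)n2)c2nn[nH]c2n1` gives 1100 nM in an assay on cells for inhibition of thyroid peroxidase (Homo sapiens), with stated times of 10 min and 15 min (a higher number here means a weaker inhibitor, a lower number a stronger inhibitor), and compound 1 `Nc1cc(Cc2ccn(Cc3cccc(Oc4ccccc4)c3)n2)c2nn[nH]c2n1` gives 1100 nM in this assay, so the two stand level. Going by the values given here, the only step known, no change at the digits printed from compound 1 to compound 2 (within the scatter), put phenyl in place of phenoxy and left the value where it was. Compound 3 `Nc1cc(Cc2ccn(Cc3cccc(Cc4ccccc4)c3)n2)c2nn[nH]c2n1` carries benzyl in place of phenyl on an aromatic carbon. Among the compounds with values here, that single flat step is the sole guide here, so the expected step of no change at the digits printed from compound 2 to compound 3 (within the scatter) is no more than the scatter. Compound 3 is therefore estimated at about 1100 nM in this assay, with a range from 550 nM to 2200 nM.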

Compound 3, half-maximal inhibitory concentration: 1900 nM
Compound 3: the middle estimate sits 1.7-fold (0.24 log units) below what was measured; low and high end bracket the measured number.
By their numbers in this assay, from the lowest: compounds 1, 2 and 3 (each within the scatter of the next).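

In this assay benzyl gives a 1.7-fold higher number from compound 2 to compound 3 (0.24 log units; within the scatter) and a 1.7-fold higher number from compound 1 to compound 3 (0.24 log units; within the scatter) so the outer ring tolerates a third kind of attachment at this place. Joined directly, through oxygen or through carbon, it gives values that cannot be told apart, which means the type of link has not yet been seen to matter here. No measured evidence explains this flat result. As far as these compounds go, whether an amine or a carboxylic acid on the outer ring would shift the value beyond the scatter remains open. So does the effect of a longer chain in place of the benzyl link.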